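Sulfonyl substituent changes and microsomal clearance

The source may hold more compounds than are shown below. What is called first, only, known or untested is meant among the compounds shown, and "the series" means these compounds.

Compound 1 `O=C(NCc1ccc(S(=O)(=O)C2CCC(F)(F)CC2)cc1)N1Cc2ccncc2C1` is the reference point of this comparison. In an ADME assay on microsomes from liver (Homo sapiens) for pharmacokinetics, read by LC-MS, with a stated time of 60 min, tested at 1 uM (a lower number here means slower removal, a higher number faster removal of the compound), compound 1 gives 6 mL/min/kg. Compound 2 `O=C(NCc1ccc(S(=O)(=O)C2CCCOC2)cc1)N1Cc2ccncc2C1` gives 7 mL/min/kg in this assay, and compound 3 `O=C(NCc1ccc(S(=O)(=O)N2CCC(O)CC2)cc1)N1Cc2ccncc2C1` gives 6 mL/min/kg. Compound 1 stands level with compound 3 at the digits shown, and the two share the lowest number of the three; the step of a 1.2-fold higher number from compound 1 to compound 2 (0.07 log units; within the scatter) and the step of no change at the digits printed from compound 1 to compound 3 (within the scatter) are both within the scatter, as is a 1.2-fold lower number from compound 2 to compound 3 (0.07 log units; within the scatter). All three numbers sit close together.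

Compound 4 `O=C(NCc1ccc(S(=O)(=O)N2CCC(N3CCCC3)CC2)cc1)N1Cc2ccncc2C1` is not yet measured. Relative to compound 1 it carries 4-(pyrrolidin-1-yl)piperidin-1-yl in place of 4,4-difluorocyclohexyl on a sulfonyl sulfur. Among the compounds with values here, the steps that bear on this change are the two exchanges at the same position, a 1.2-fold higher number from compound 1 to compound 2 (0.07 log units; within the scatter) and no change at the digits printed from compound 1 to compound 3 (within the scatter); neither moved the number beyond the scatter, and neither involved the group that enters here, so there is no direct precedent for it. On that basis no step beyond the scatter is expected in this assay, though the absence of a precedent widens the range. Compound 4 is therefore estimated at 7 mL/min/kg, with a range from 3 mL/min/kg to 16 mL/min/kg. This estimate corresponds to an expected step of a 1.2-fold higher number from compound 1 to compound 4 (0.07 log units; within the scatter).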

Compound 4, clearance: 6 mL/min/kg
Compound 4: the middle estimate sits 1.2-fold (0.07 log units) above what was measured; the measured number falls inside the stated range.
By their numbers in this assay, from the lowest: compounds 1, 3, 4 and 2 (each within the scatter of the next).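

In this assay, the sulfonyl sulfur also carries 4-(pyrrolidin-1-yl)piperidin-1-yl, which brings a five-membered and a six-membered non-aromatic ring, each with a hetero atom, with no step beyond the scatter (no change at the digits printed from compound 1 to compound 4 (within the scatter); a 1.2-fold lower number from compound 2 to compound 4 (0.07 log units; within the scatter)). The series also now has an exchange away from the sulfonyl sulfur: pyrrolidin-1-yl in place of hydroxy on a saturated ring carbon also stays within the scatter (no change at the digits printed from compound 3 to compound 4 (within the scatter)), so neither site has yet shown a step that can be read as a real difference. No supporting data bear on why the number holds across these exchanges.

From the compounds shown here alone, whether a carboxylic acid on that saturated ring carbon, or an open-chain amine such as diethylamino on the sulfonyl sulfur, would give a step beyond the scatter remains open. With all four compounds sharing one core, the compounds shown also say nothing about how changes to the core of compound 1 would read in this assay.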